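The compounds below may be only part of what the source reports. "The series", "measured", "known", "first", "only" and "open" are said of these compounds alone.

Compound 1 `CC(C)(C)c1ccc(CNCCCNS(=O)(=O)c2cc(C(F)(F)F)cc(C(F)(F)F)c2)cc1` sits in the middle of the three measured numbers: in a functional assay on A2780 cells (Homo sapiens) for inhibition, read by MTT assay, with a stated time of 72 h (on this read-out lower numbers stand for stronger inhibition of growth and higher numbers for weaker inhibition of growth), compound 1 gives 2900 nM. Compound 2 `O=S(=O)(NCCCCNCc1ccc(Br)cc1)c1cc(C(F)(F)F)cc(C(F)(F)F)c1` gives 2100 nM in this assay, a gap from compound 1 that lies within the usual scatter, so the two cannot be ordered. For the measured compounds named here, compound 3 `CN(CCCNS(=O)(=O)c1cc(C(F)(F)F)cc(C(F)(F)F)c1)Cc1ccccc1` gives 28000 nM in this assay, and the single recorded step between measured compounds, a 13-fold higher number from compound 2 to compound 3 (1.12 log units; beyond the scatter), shows that rebuilding the amine end of the chain can weaken growth inhibition sharply.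

Compound 4 `O=S(=O)(NCCCNCc1cccc(Cl)c1)c1cc(C(F)(F)F)cc(C(F)(F)F)c1` keeps the shared core of compound 1 and changes only the aryl group at the amine end: 3-chlorophenyl in place of 4-(tert-butyl)phenyl on a saturated chain carbon bound to an amine nitrogen. Going by the values given here, no measured step swaps one substituted phenyl for another at this position; the one measured step concerns the same region of the molecule but alters the amine itself as well as the ring, so it speaks only loosely to this change. Among the compounds with values here, with no direct precedent, the expectation is a small shift at most, giving a 1.2-fold higher number from compound 1 to compound 4 (0.08 log units; within the scatter) as the estimated step. Compound 4 is therefore expected to give about 3500 nM in this assay, with a likely range from 1200 nM to 10000 nM.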

Compound 4, concentration for 50% growth inhibition: 2200 nM
For compound 4 the middle estimate is 1.6-fold (0.20 log units) above the measured one; measured number inside the range.
By their numbers in this assay, from the lowest: compounds 2, 4 and 1 (each within the scatter of the next); then compound 3.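

Replacing the 4-(tert-butyl)phenyl group with 3-chlorophenyl on a saturated chain carbon bound to an amine nitrogen gives, in this assay, a 1.3-fold lower number from compound 1 to compound 4 (0.12 log units; within the scatter), so the two ring groups cannot be told apart here, even though they carry different substituents. For the compounds shown here, compound 4 also cannot be separated from the bromine-bearing compound 2, as a 1.0-fold higher number from compound 2 to compound 4 (0.02 log units; within the scatter) shows, whereas a 13-fold lower number from compound 3 to compound 4 (1.10 log units; beyond the scatter) is a second large step involving compound 3, which leaves compound 3 standing apart from compounds 1, 2 and 4, the only compound of the four with a methyl group on the amine nitrogen. Nothing available explains why the numbers fall this way.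

Compound 3 also differs from the others in its unsubstituted phenyl ring, so the compounds shown cannot say whether the methyl group, the bare ring or both go with its weak growth inhibition. On these data alone, it also remains open whether this tolerance extends to a pyridine ring or a carboxylic acid on the ring in place of the 3-chlorophenyl group.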